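Fluoro for Hydrogen on a Fused Ring System

The source may hold more compounds than are shown below. What is called first, only, known or untested is meant among the compounds shown, and "the series" means these compounds.

Among the measured compounds shown here, compound 2 `c1ccc(-c2nn(-c3ccccc3)cc2-c2nc3ccccc3[nH]2)cc1` gives 3190 nM in a functional assay on MCF7 cells (Homo sapiens) for antiproliferative activity, read by MTT assay, with a stated time of 48 h (on this read-out lower numbers stand for stronger inhibition and higher numbers for weaker inhibition), the lower of the two numbers known; compound 1 `O=Cc1cn(-c2ccccc2)nc1-c1ccc(Cl)cc1` gives 9650 nM in this assay, a gap that lies beyond the usual scatter. Compound 3 `Fc1ccc2[nH]c(-c3cn(-c4ccccc4)nc3-c3ccccc3)nc2c1` differs from compound 2 by one change: fluoro in place of hydrogen on an aromatic carbon. For the measured compounds named here, no step between measured compounds shows what such a change does here, so in this assay a small step is expected, within the scatter, in no certain direction. The step from compound 2 to compound 3 in this assay is estimated at a 1.2-fold lower number from compound 2 to compound 3 (0.09 log units; within the scatter). Compound 3 is expected to give 2600 nM in this assay, within 1000 nM to 7500 nM.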

Compound 3, half-maximal inhibitory concentration: 2430 nM
The estimate for compound 3 lay 1.1-fold (0.03 log units) above the measured number; the range from low to high includes it.
By their numbers in this assay, from the lowest: compounds 3 and 2 (each within the scatter of the next); then compound 1.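

In this assay fluoro in place of hydrogen on an aromatic carbon of the six-membered aromatic ring of carbon only gives a 1.3-fold lower number from compound 2 to compound 3 (0.12 log units; within the scatter) and so leaves the two compounds within the scatter of each other. This is the first step shown at this position, and it shows that the position carries a fluoro without a clear separation in the read-out. Nothing shown here offers an explanation for this result. From the compounds shown here alone, whether an amine, a carboxylic acid or a methoxy group at this position would give a step beyond the scatter remains open.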